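Cytotoxicity in HEL Cells: Three Measured Compounds and One Estimate

A few compounds are considered here, and "the series" means these few. Any claim that something is new, unique, unknown or untested is made for them only; others in the source may bear on it.

The measured compounds and their values in an ADME assay on HEL cells (Homo sapiens) for cytotoxicity, read by cell counting, with a stated time of 3 days; a lower number here means that less compound is tolerated, a higher number that more compound is tolerated:
compound 1 `CCCCCc1ccc(-c2oc3nc(=O)n([C@H]4C[C@H](OC(C)=O)[C@@H](COC(C)=O)O4)cc3c2C#Cc2ccc(C)cc2)cc1`: 100000 nM
compound 2 `CCCCCc1ccc(-c2oc3nc(=O)n([C@H]4C[C@H](OC(C)=O)[C@@H](COC(C)=O)O4)cc3c2C#CCO)cc1`: 100000 nM
Compound 3 `CC(=O)OC[C@H]1O[C@@H](n2cc3c(C#CCO)c(-c4ccc(C)cc4)oc3nc2=O)C[C@@H]1OC(C)=O` reaches only a limit of the assay, > 100000 nM.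

The step of no change at the digits printed from compound 2 to compound 1 (within the scatter) accompanies the change (4-methylphenyl in place of hydroxymethyl on a triple-bonded carbon). The other step, a number no lower from compound 2 to compound 3 (the limit leaves the size open), accompanies the change (hydrogen in place of butyl on a saturated chain carbon bound to an aromatic carbon); its size is not readable because compound 3 sits at the limit of > 100000 nM in this assay, at which 1 of the 3 values shown sits.

Compound 4 `CC(=O)OC[C@H]1O[C@@H](n2cc3c(C#Cc4ccc(C)cc4)c(-c4ccc(C)cc4)oc3nc2=O)C[C@@H]1OC(C)=O` has not been measured in this assay. It arises from compound 3 by 4-methylphenyl in place of hydroxymethyl on a triple-bonded carbon. This is the same change as that from compound 2 to compound 1, and the only other instance of it among these compounds; the place of the change is described in the same words for both pairs, so the change is the same. The cores of the two pairs differ as described by hydrogen in place of butyl on a saturated chain carbon bound to an aromatic carbon.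

The expected step from compound 3 is a number no higher from compound 3 to compound 4 (the limit leaves the size open), resting on the fact that compound 2 to compound 1 showed no change at the digits printed from compound 2 to compound 1 (within the scatter). Since compound 3 already sits at a limit, compound 4 is expected to give 100000 nM, most probably again reported only as a limit, with a range from 50000 nM to 200000 nM.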

Compound 4, minimum cytotoxic concentration: 60000 nM
Estimate against measurement, compound 4: 1.7-fold (0.22 log units) above; the measured number falls inside the stated range.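

In this assay, 4-methylphenyl in place of hydroxymethyl on a triple-bonded carbon gives an at least 1.6-fold lower number from compound 3 to compound 4 (0.22 log units; that floor lies within the scatter), and set beside its earlier instance on the other core, the change reads: the same change on two cores in this assay, no change at the digits printed (within the scatter) from compound 2 to compound 1 and an at least 1.6-fold lower number (0.22 log units; that floor lies within the scatter) from compound 3 to compound 4; the limit leaves it open whether they differ. Hydrogen in place of butyl on a saturated chain carbon bound to an aromatic carbon gives a 1.7-fold lower number from compound 1 to compound 4 (0.22 log units; within the scatter), and the same comparison across cores reads: the same change on two cores in this assay, a number no lower (the limit leaves the size open) from compound 2 to compound 3 and a 1.7-fold lower number (0.22 log units; within the scatter) from compound 1 to compound 4; the limit leaves it open whether they differ. This shows that neither change produces a step printed as beyond the scatter on the cores compared here, but it does not show that either change carries over unaltered from one core to the other, as compound 3 stands only at a limit of the assay and the steps involving it cannot be read in full.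

The compounds shown leave open whether a different group on the triple-bonded carbon, such as an amine or a carboxylic acid in place of hydroxymethyl, would give a step beyond the scatter. They also leave open how a longer chain in place of the pentyl group, or a free hydroxyl in place of either acetate, would read in this assay.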